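Fluoro to Methyl on the Aryl Ring: an Expected Dose

The source may hold more compounds than are shown below. What is called first, only, known or untested is meant among the compounds shown, and "the series" means these compounds.

Measured compounds:
compound 1 `O=C(/N=C/c1ccc(Cl)cc1)Nc1ccc2c(c1)C(=O)C(=O)N2CN1CCCCC1`: 300 mg/kg
compound 2 `O=C(/N=C/c1ccc(F)cc1)Nc1ccc2c(c1)C(=O)C(=O)N2CN1CCCCC1`: 100 mg/kg

In a functional assay on the whole organism (strain Swiss albino) with Mus musculus as the target, with a stated time of 0.5 h (on this read-out lower numbers stand for an effect already at smaller amounts and higher numbers for an effect only at larger amounts of compound), compound 1 gives 300 mg/kg, and compound 2 gives 100 mg/kg, the lowest of the two numbers. Among the measured compounds shown here, the only measured step, a 3.0-fold lower number from compound 1 to compound 2 (0.48 log units; beyond the scatter), came with fluoro in place of chloro on an aromatic carbon. Compound 3 `Cc1ccc(/C=N/C(=O)Nc2ccc3c(c2)C(=O)C(=O)N3CN2CCCCC2)cc1` is the next member: methyl in place of fluoro on an aromatic carbon. For the measured compounds named here, no measured step covers methyl, so the single halogen swap offers only indirect guidance; it shows that a change at this position can move the number modestly in either direction. Compound 3 is therefore expected to stay near compound 2, with a slight drift toward a higher number, a 1.5-fold higher number from compound 2 to compound 3 (0.18 log units; within the scatter). The estimate for compound 3 in this assay is 150 mg/kg, within a range of 75 mg/kg to 300 mg/kg.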

Compound 3, minimum effective dose: 300 mg/kg
The estimate for compound 3 lay 2.0-fold (0.30 log units) below the measured number; low and high end bracket the measured number.
By their numbers in this assay, from the lowest: compound 2; then compounds 1 and 3 (each within the scatter of the next).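

Methyl in place of fluoro in this assay gave a 3.0-fold higher number from compound 2 to compound 3 (0.48 log units; beyond the scatter), so compound 2 now stands apart from two other compounds instead of one. Methyl in place of chloro gave no change at the digits printed from compound 1 to compound 3 (within the scatter), which shows that this position tolerates a move from a halogen to a carbon group with no visible shift, and that the lower number belongs to the 4-fluorophenyl compound alone among the three. Nothing available here bears on why fluoro stands apart in this way.

The compounds shown leave open whether the lower number of compound 2 is particular to fluoro or would also appear with a hydroxyl, an amine or a nitrile on the same carbon. They also leave open whether the gap between fluoro and the other two groups would survive a change elsewhere in the shared core.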